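A few compounds are considered here, and "the series" means these few. Any claim that something is new, unique, unknown or untested is made for them only; others in the source may bear on it.

Going by the values given here, in a functional assay on Huh-7 cells (Homo sapiens) for antiproliferative activity, with a stated time of 48 h (on this read-out lower numbers stand for stronger inhibition and higher numbers for weaker inhibition), compound 1 `CC(=O)c1ccc(-c2ccc(N3CCCC3)nn2)cc1` gives 30000 nM as the only actual number available. Compound 2 `CCN(CC)c1ccc(-c2cccc(Cl)c2)nn1` stands at > 25000 nM as a limit and not a number. Among the compounds with values here, compound 3 `CCN(CC)c1ccc(-c2ccc(C(C)=O)cc2)nn1` keeps the core of compound 1 and carries diethylamino in place of pyrrolidin-1-yl on an aromatic carbon as its single change. Within the data shown here, no measured step bears on this swap, so no shift beyond the usual scatter is expected in this assay for now. The estimated step is no change at the digits printed from compound 1 to compound 3 (within the scatter) in size. Compound 3 is estimated at 30000 nM with an expected range from 12000 nM to 70000 nM on this read-out.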

Compound 3, half-maximal inhibitory concentration: 25000 nM
Estimate against measurement, compound 3: 1.2-fold (0.08 log units) above, and the stated range covers the measured number.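

In this assay, diethylamino in place of pyrrolidin-1-yl on an aromatic carbon next to the ring nitrogen gives a 1.2-fold lower number from compound 1 to compound 3 (0.08 log units; within the scatter). At this position, then, the ring of pyrrolidin-1-yl can give way to an open-chain group with the same heavy-atom count without a shift beyond the scatter. Compound 2 stands at a limit and not a number: the limit of > 25000 nM in this assay, at which 1 of the 3 values shown sits.

The compounds shown leave open whether a different amine at this position, such as morpholine or dimethylamino, would move the number beyond the scatter.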